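Thiosemicarbazide amidrazones: cyclic amine swap at thiocarbonyl

The source may report more compounds than this note shows. Statements on the series, on what has been measured and on what is new or still open speak of the compounds shown alone.

Measured so far:
compound 1, `N/C(=N\NC(=S)N1CCCC1)c1ccc(F)cn1`, gives 86.6%
compound 2, `N/C(=N\NC(=S)N1CCCCC1)c1ccccn1`, gives 88.5%

Both numbers come from a functional assay on A-375 cells (Homo sapiens) for cytotoxicity, read by MTT assay, with a stated time of 72 h, tested at 100 uM; a higher number here means more inhibition of growth at the concentration tested, a lower number less inhibition of growth. In this assay compound 1 gives 86.6% and compound 2 gives 88.5%; the gap between them lies within the usual scatter, so compound 1 does not stand apart from compound 2 and the two are read as the same level of growth inhibition. Among the measured compounds shown here, no step between measured compounds is at hand, since compound 1 and compound 2 differ in two places at once.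

Compound 3, `N/C(=N\NC(=S)N1CCOCC1)c1ccc(F)cn1`, is not yet measured. It differs from compound 1 in one place: morpholin-4-yl in place of pyrrolidin-1-yl on a thiocarbonyl carbon. For the measured compounds named here, the measured pair gives no direct guide to such a swap of the cyclic amine; the only hint is that compound 1 and compound 2, carrying two different cyclic amines, sit at the same level. The step is therefore expected to be small, with a slight lean toward a somewhat lower number, as compound 1 with 86.6% already sits close to full inhibition and has little room upward. For compound 3 the expected step is a number 4.6 percentage points lower from compound 1 to compound 3 (within the scatter). Compound 3 is expected to give 82%, within a range from 62% to 93%.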

Compound 3, percent growth inhibition at one concentration: 86.2%
Compound 3: the middle estimate sits 4.2 percentage points below what was measured; the range from low to high includes it.
By their numbers in this assay, from the lowest: compounds 3, 1 and 2 (each within the scatter of the next).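

In this assay, among the compounds shown here, morpholin-4-yl in place of pyrrolidin-1-yl on a thiocarbonyl carbon gives a number 0.4 percentage points lower from compound 1 to compound 3 (within the scatter), the first step that can be read at a single place. At this position, a six-membered non-aromatic ring with 2 hetero atoms and 1 hydrogen-bond acceptor therefore holds the same level of growth inhibition as a five-membered non-aromatic ring with 1 hetero atom, so the ring oxygen of morpholin-4-yl shows no separate mark in this read-out. No measured property or other supporting data at hand accounts for this flat result.

Still open, from the compounds shown here alone, is whether an open-chain dimethylamino group or a 4-methylpiperazin-1-yl ring on the same thiocarbonyl carbon would hold this level on the core of compound 1. The piperidine ring of compound 2 also remains unplaced on that core, as compound 2 differs from compound 1 in two places and its separate contribution cannot be read from the compounds shown.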